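Swapping methoxy for methyl on a shared core

The compounds below may be only part of what the source reports. "The series", "measured", "known", "first", "only" and "open" are said of these compounds alone.

Compound 1, `COc1ncnc2c1c(-c1ccoc1)cn2[C@@H]1O[C@H](CO)[C@@H](O)[C@H]1O`, was tested in a functional assay on HeLa S3 cells (Homo sapiens) for antiproliferative activity, read by XTT assay, with a stated time of 72 h (a higher number here means a weaker inhibitor, a lower number a stronger inhibitor), where compound 1 gives 1790 nM. Compound 2, `Cc1ncnc2c1c(-c1ccoc1)cn2[C@@H]1O[C@H](CO)[C@@H](O)[C@H]1O`, differs from it by methyl in place of methoxy on an aromatic carbon. In this assay compound 2 reaches only > 20000 nM, which is a limit of the assay and not a number, as described in the limit of > 20000 nM in this assay, at which 1 of the 3 values shown sits. The change thus produced an at least 11-fold higher number from compound 1 to compound 2 (1.04 log units; beyond the scatter). Compound 3, `COc1ncnc2c1c(-c1cccs1)cn2[C@@H]1O[C@H](CO)[C@@H](O)[C@H]1O`, carries a different core, and the difference between the cores is thiophen-2-yl in place of furan-3-yl on an aromatic carbon. In this assay compound 3 gives 1760 nM, with a step of a 1.0-fold lower number from compound 1 to compound 3 (0.01 log units; within the scatter), so the two cores look alike here. Compound 4, `Cc1ncnc2c1c(-c1cccs1)cn2[C@@H]1O[C@H](CO)[C@@H](O)[C@H]1O`, has not yet been measured. Against compound 3 it shows (methyl in place of methoxy on an aromatic carbon); the place of the change is described in the same words as for the step from compound 1 to compound 2, so it is the same change on the other core. The expected step is a 14-fold higher number from compound 3 to compound 4 (1.15 log units; beyond the scatter), because the same change gave an at least 11-fold higher number from compound 1 to compound 2 (1.04 log units; beyond the scatter) and the two cores have shown no difference so far. Compound 4 is therefore expected to give 25000 nM. Its expected range runs from 12000 nM to 60000 nM, and the assay will most likely again report only a limit.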

Compound 4, half-maximal inhibitory concentration: > 15000 nM
Compound 4 was reported as a limit (the forecaster's own chance of this, stated with the estimate: 65%); the middle value does not contradict the limit.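

Methyl in place of methoxy weakens the compound on the core carrying thiophen-2-yl, as it did on the core carrying furan-3-yl: in this assay there is an at least 8.5-fold higher number from compound 3 to compound 4 (0.93 log units; beyond the scatter). Compound 4 is reported only as a limit, > 15000 nM, so this step is a minimum and not an exact size. The change therefore points the same way on both cores, but this does not show that its size carries over unchanged, and the step from compound 2 to compound 4 cannot be read: the same change on two cores in this assay, an at least 11-fold higher number (1.04 log units; beyond the scatter) from compound 1 to compound 2 and an at least 8.5-fold higher number (0.93 log units; beyond the scatter) from compound 3 to compound 4; the limit leaves it open whether they differ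

As far as these compounds go, what remains open is the true level of compound 2 and compound 4, and whether the change behaves alike on any core beyond these two. Also open is what other groups would do on the same aromatic carbon, such as an amine or an ethoxy group, as the compounds shown carry only methoxy and methyl there.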